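Swapping an Ethynyl for a Benzofuranyl Group

The compounds below may be only part of what the source reports. "The series", "measured", "known", "first", "only" and "open" are said of these compounds alone.

Among the three compounds measured so far, compound 1 `C#Cc1cn([C@@H]2O[C@H](CO)[C@@H](O)[C@H]2O)c2ncnc(OC)c12` gives the lowest number: in a functional assay on HL-60 cells (Homo sapiens) for antiproliferative activity, read by XTT assay, with a stated time of 72 h (on this read-out higher numbers stand for weaker inhibition and lower numbers for stronger inhibition), compound 1 gives 190 nM. Compound 3 `C#Cc1cn([C@@H]2O[C@H](CO)[C@@H](O)[C@H]2O)c2ncnc(N(C)C)c12` gives 290 nM, and the step of a 1.5-fold higher number from compound 1 to compound 3 (0.18 log units; within the scatter) stays within the scatter. Compound 2 `O=c1[nH]cnc2c1c(-c1ccsc1)cn2[C@@H]1O[C@H](CO)[C@@H](O)[C@H]1O` gives 12000 nM, but it differs from compound 1 in two places, so no single step can be read from it. Compound 4 `COc1ncnc2c1c(-c1cc3ccccc3o1)cn2[C@@H]1O[C@H](CO)[C@@H](O)[C@H]1O` differs from compound 1 by 1-benzofuran-2-yl in place of ethynyl on an aromatic carbon. Within the data shown here, no measured step covers this change, so the expectation rests on compound 1 alone. The estimated value for compound 4 is 100 nM, ranging from 20 nM to 800 nM, which means an expected step of a 1.9-fold lower number from compound 1 to compound 4 (0.28 log units; within the scatter).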

Compound 4, half-maximal inhibitory concentration: 4470 nM
Compound 4: the middle estimate sits 45-fold (1.65 log units) below what was measured; measured number outside the range, above it.
By their numbers in this assay, from the lowest: compounds 1 and 3 (each within the scatter of the next); then compound 4; then compound 2.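

In this assay, putting 1-benzofuran-2-yl in place of ethynyl on this aromatic carbon gives a 24-fold higher number from compound 1 to compound 4 (1.37 log units; beyond the scatter), so this carbon does not accept every group alike. This is the first single change at this carbon among the compounds shown, since the earlier readable step changed a different place. Nothing measured here explains the rise in the number.

As far as these compounds go, it remains open whether a plain phenyl ring or a longer chain such as propynyl on this carbon would keep the number close to that of compound 1.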